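The source may hold more compounds than are shown below. What is called first, only, known or untested is meant among the compounds shown, and "the series" means these compounds.

Measured so far:
- compound 1, `CC(Oc1ccc(Oc2ccc(C(F)(F)F)cc2)cc1)C(=O)Cn1nnc(-c2ccccc2)n1` — 160 nM
- compound 2, `CC(Oc1ccc(Oc2ccc(F)cc2)cc1)C(=O)Cn1nnc(-c2ccc(Cl)cc2)n1` — 42 nM

In an assay on microsomes from brain for inhibition of Fatty-acid amide hydrolase 1 (Rattus norvegicus), read by fluorescence and HPLC, with a stated time of 60 min (on this read-out lower numbers stand for stronger inhibition and higher numbers for weaker inhibition), compound 2 gives 42 nM, the lower of the two numbers recorded; compound 1 gives 160 nM, a gap beyond the usual scatter. For the measured compounds named here, compound 1 and compound 2 differ at two places at once, on the phenoxy ring and on the aryl group attached to the tetrazole, so no single-place step is available and the two values cannot be assigned to either change alone.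

Compound 3, `CC(Oc1ccc(Oc2ccc(C(F)(F)F)cc2)cc1)C(=O)Cn1nnc(-c2ccc(Cl)cc2)n1`, differs from compound 2 in one place: trifluoromethyl in place of fluoro on an aromatic carbon. Going by the values given here, the trifluoromethyl-bearing phenoxy ring of compound 3 is the one carried by compound 1, while the chlorophenyl on the tetrazole is kept from compound 2. Among the compounds with values here, with no measured step for this change, the expectation is a shift of modest size in this assay, most likely toward a somewhat higher number than compound 2, but possibly none beyond the scatter. For compound 3 the expected step is a 1.7-fold higher number from compound 2 to compound 3 (0.22 log units; within the scatter). The estimate for compound 3 is 70 nM, with a range from 25 nM to 200 nM.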

Compound 3, half-maximal inhibitory concentration: 300 nM
Compound 3: the middle estimate sits 4.3-fold (0.63 log units) below what was measured, outside the stated range (above it).
By their numbers in this assay, from the lowest: compound 2; then compounds 1 and 3 (each within the scatter of the next).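

In this assay, the change from 4-fluorophenoxy to 4-(trifluoromethyl)phenoxy can now be read on its own, and it gives a 7.1-fold higher number from compound 2 to compound 3 (0.85 log units; beyond the scatter) with the 4-chlorophenyl on the tetrazole held constant. The other single-place change, chloro in place of hydrogen on the aryl group attached to the tetrazole, gives a 1.9-fold higher number from compound 1 to compound 3 (0.27 log units; within the scatter) with trifluoromethyl kept on the phenoxy ring, so in this pair that change cannot be told from the scatter. Nothing on hand explains the size of the step from fluoro to trifluoromethyl.

From the compounds shown here alone, each step is read against one background only: fluoro against trifluoromethyl with chloro on the tetrazole aryl group, and chloro against hydrogen with trifluoromethyl on the phenoxy ring, so whether either step holds once the other group changes remains open. Hydrogen, methoxy or a nitrile in the same place on the phenoxy ring would show whether the higher number follows trifluoromethyl alone or whether fluoro is the group that stands apart.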